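Working notes: changing the group on sulfur

The source may hold more compounds than are shown below. What is called first, only, known or untested is meant among the compounds shown, and "the series" means these compounds.

Measured in a functional assay on NCI/ADR-RES cells (Homo sapiens) for inhibition, read by luminescence, with a stated time of 72 h; on this read-out lower numbers stand for stronger inhibition and higher numbers for weaker inhibition:
- compound 1 `Nc1ncnc2c1nc(Sc1cc3c(cc1Br)CCO3)n2CCC1CCN(C=O)CC1`: 1800 nM
- compound 2 `Nc1ncnc2c1nc(Sc1cc3occc3cc1Br)n2CCC1CCN(C=O)CC1`: 1100 nM

The two values lie within the scatter of each other, so compound 2, at 1100 nM, cannot be separated from compound 1. Compound 3 `Nc1ncnc2c1nc(Sc1cc3c(cc1Br)CCC3)n2CCC1CCN(C=O)CC1` changes the group on a sulfur: 6-bromo-2,3-dihydro-1H-inden-5-yl in place of 5-bromo-1-benzofuran-6-yl on a sulfur. Among the compounds with values here, one measured step bears on this, a 1.6-fold lower number from compound 1 to compound 2 (0.21 log units; within the scatter), which altered the same group and stayed within the scatter. No shift beyond the scatter is therefore expected in this assay, and the expected change is a 1.4-fold higher number from compound 2 to compound 3 (0.13 log units; within the scatter). Compound 3 is estimated at 1500 nM, with an expected range of 600 nM to 3800 nM.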

Compound 3, half-maximal inhibitory concentration: 230 nM
Compound 3: middle estimate off by 6.5-fold (0.81 log units), on the high side, outside the stated range (below it).
By their numbers in this assay, from the lowest: compound 3; then compounds 2 and 1 (each within the scatter of the next).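

In this assay the group on sulfur does move the number: there is a 4.8-fold lower number from compound 2 to compound 3 (0.68 log units; beyond the scatter) and also a 7.8-fold lower number from compound 1 to compound 3 (0.89 log units; beyond the scatter) and both lie beyond the scatter, which the step between the two oxygen-bearing groups did not. Among these three compounds, the all-carbon 6-bromo-2,3-dihydro-1H-inden-5-yl group stands apart from both groups carrying a ring oxygen. Nothing available explains this difference.

Still open, as far as these compounds go, is whether a five-membered ring carrying a nitrogen, or a six-membered non-aromatic carbon ring, would hold the number of compound 3 on the same sulfur.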